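Chloro gives way to methoxy on the shared core

The source may hold more compounds than are shown below. What is called first, only, known or untested is meant among the compounds shown, and "the series" means these compounds.

In a functional assay for inhibition, with Rattus norvegicus as the target (a higher number here means a weaker inhibitor, a lower number a stronger inhibitor), compound 2 `CC(C)(C)/N=c1\c(O)c(O)\c1=N/c1cccnc1Cl` gives 1770 nM and sits within the scatter of compound 1 `CC(C)(C)/N=c1\c(O)c(O)\c1=N/c1cccnc1` at 2800 nM in this small set. Compound 3 `COc1ncccc1/N=c1\c(O)c(O)\c1=N/C(C)(C)C` carries methoxy in place of chloro on an aromatic carbon next to the ring nitrogen. Within the data shown here, the only measured step at this place is a 1.6-fold lower number from compound 1 to compound 2 (0.20 log units; within the scatter) for chloro in place of hydrogen. Among the measured compounds shown here, no methoxy compound has a number yet, so nothing beyond the scatter is expected in this assay here. The expected 1.1-fold higher number from compound 2 to compound 3 (0.05 log units; within the scatter) is therefore small. Compound 3 is estimated at 2000 nM with 700 nM to 6000 nM as its likely range.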

Compound 3, half-maximal inhibitory concentration: 2560 nM
Compound 3: middle estimate off by 1.3-fold (0.11 log units), on the low side; low and high end bracket the measured number.
By their numbers in this assay, from the lowest: compounds 2, 3 and 1 (each within the scatter of the next).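

In this assay, methoxy in place of chloro next to the ring nitrogen gives a 1.4-fold higher number from compound 2 to compound 3 (0.16 log units; within the scatter), and methoxy in place of hydrogen gives a 1.1-fold lower number from compound 1 to compound 3 (0.04 log units; within the scatter). Hydrogen, chloro and methoxy therefore cannot be told apart at this place, even though methoxy adds a heavy atom and a hydrogen-bond acceptor compared with chloro. No available evidence accounts for this lack of separation. On these data alone, whether an amine, a carboxylic acid or a longer chain here would move the number beyond the scatter remains open.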